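Chloro on the Phenyl of a Chalcone: Expected Effect on Growth

The source may hold more compounds than are shown below. What is called first, only, known or untested is meant among the compounds shown, and "the series" means these compounds.

Compound 1 `COc1cc(/C=C/C(=O)c2cccc(-n3cc(-c4ccccc4)[nH]c3=O)c2)ccc1O` is one of three related compounds tested in a functional assay on SK-MEL-2 cells (Homo sapiens) for inhibition; on this read-out higher numbers stand for weaker inhibition of growth and lower numbers for stronger inhibition of growth. In this assay compound 1 gives 3650 nM, the highest of the three numbers, yet within the scatter of the other two. Compound 2 `COc1cc(/C=C/C(=O)c2cccc(-n3cc(-c4ccccc4)[nH]c3=O)c2)cc(OC)c1OC` gives 2060 nM, and compound 3 `COc1cc(/C=C/C(=O)c2cccc(-n3cc(-c4cc(OC)c(OC)c(OC)c4)[nH]c3=O)c2)cc(OC)c1OC` gives 3020 nM; the step of a 1.5-fold higher number from compound 2 to compound 3 (0.17 log units; within the scatter) changes the number by less than the scatter. Compound 4 `COc1cc(/C=C/C(=O)c2cccc(-n3cc(-c4ccc(Cl)cc4)[nH]c3=O)c2)ccc1O` differs from compound 1 by chloro in place of hydrogen on an aromatic carbon. Among the compounds with values here, no measured step touches this exact change; the one comparable change on the same phenyl, from compound 2 to compound 3, stayed within the scatter. Compound 4 is therefore expected to show a 1.2-fold lower number from compound 1 to compound 4 (0.09 log units; within the scatter), landing near 3000 nM, with a range of 1200 nM to 7500 nM.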

Compound 4, concentration for 50% growth inhibition: 3660 nM
Compound 4: the middle estimate sits 1.2-fold (0.09 log units) below what was measured; the range from low to high includes it.
By their numbers in this assay, from the lowest: compounds 2, 3, 1 and 4 (each within the scatter of the next).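

In this assay, going from phenyl to 4-chlorophenyl gives a 1.0-fold higher number from compound 1 to compound 4 (0.00 log units; within the scatter) and so leaves the number effectively unchanged. Together with the 3,4,5-trimethoxyphenyl change, which gave a 1.5-fold higher number from compound 2 to compound 3 (0.17 log units; within the scatter) on a different parent, this makes two unlike substitutions on this phenyl that stay within the scatter. No measurement here explains why the number holds.

As far as these compounds go, whether an amine or a carboxylic acid in the same place would shift the number remains open. So does whether chloro would behave the same way on compound 2.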